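The source may report more compounds than this note shows. Statements on the series, on what has been measured and on what is new or still open speak of the compounds shown alone.

In a functional assay on A-375 cells (Homo sapiens) for antiproliferative activity, read by CCK-8 assay, with a stated time of 72 h, tested at 2 uM (a higher number here means a stronger effect of the compound at the concentration tested, a lower number a weaker effect), compound 1 `Nc1ccccc1NC(=O)c1ccc(CSC(=S)N2CCN(Cc3ccccn3)CC2)cc1` gives 20.7%, the lowest of the three numbers in hand. Compound 3 `Nc1ccccc1NC(=O)c1ccc(CSC(=S)N2CCCC2)cc1` gives 30.2%, a value within the scatter of compound 1, while compound 2 `CCN(Cc1ccncc1)C(=S)SCc1ccc(C(=O)Nc2ccccc2N)cc1` gives 67.2%, a value well beyond it. Among the measured compounds shown here, the only step that pairs two compounds differing in a single place is a number 37 percentage points lower from compound 2 to compound 3 (beyond the scatter); it swaps the group on the thiocarbonyl carbon, a place that the step to compound 4 does not touch. Compound 4 `Nc1ccccc1NC(=O)c1ccc(CSC(=S)N2CCN(Cc3cccnc3)CC2)cc1` differs from compound 1 in one respect: pyridin-3-yl in place of pyridin-2-yl on a saturated chain carbon bound to an amine nitrogen in a ring. For the measured compounds named here, no measured pair isolates this exchange, so nothing in the data points to a move in this assay beyond the scatter in either direction. The expected step is therefore a number 2.3 percentage points higher from compound 1 to compound 4 (within the scatter), essentially no change. For compound 4 the estimate in this assay is 23%, expected to lie between 8% and 42%.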

Compound 4, a percentage reported as inhibition, at one concentration (the size of the read-out at that concentration, not a potency): 31.5%
Compound 4: the middle estimate sits 8.5 percentage points below what was measured; the range from low to high includes it.
By their numbers in this assay, from the lowest: compounds 1, 3 and 4 (each within the scatter of the next, the first and the last beyond it); then compound 2.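

Exchanging pyridin-2-yl for pyridin-3-yl on a saturated chain carbon bound to an amine nitrogen in a ring gives, in this assay, a number 10.8 percentage points higher from compound 1 to compound 4 (beyond the scatter). The two groups carry the same atoms and the same counts of hydrogen-bond donors and acceptors, so the read-out at this place depends on how those atoms are joined, not only on which atoms are present. Among the compounds shown here, the earlier compounds could not show this: their one step replaced the whole group on the thiocarbonyl carbon, and no pair changed anything at this place alone.

How a plain phenyl ring on the same carbon would read remains an open question. Nothing available explains why the exchange moves the number.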